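Swapping the aryl group on the triazole of compound 1

The compounds below may be only part of what the source reports. "The series", "measured", "known", "first", "only" and "open" are said of these compounds alone.

Measured so far:
Compound 1 `COc1ccc(-n2cc(COc3cccc(NC(=O)Nc4ccc(Cl)c(C(F)(F)F)c4)c3)nn2)cc1` gives 4680 nM in a functional assay on HepG2 cells (Homo sapiens) for inhibition, read by MTT assay, with a stated time of 72 h; a higher number here means a weaker inhibitor, a lower number a stronger inhibitor.
Compound 2 `CC(C)c1cccc(-n2cc(COc3cccc(NC(=O)Nc4ccc(Cl)c(C(F)(F)F)c4)c3)nn2)c1` gives 3250 nM in this assay.
Compound 3 `O=C(Nc1cccc(OCc2cn(-c3cccc(F)c3)nn2)c1)Nc1ccc(Cl)c(C(F)(F)F)c1` gives 2120 nM in this assay.

Of these three numbers, compound 1 carries the highest, so it is the starting point with the most room for a lower number. Compound 4 `O=C(Nc1cccc(OCc2cn(-c3ccccc3C(F)(F)F)nn2)c1)Nc1ccc(Cl)c(C(F)(F)F)c1` is the unmeasured partner. It differs from compound 1 in one place: 2-(trifluoromethyl)phenyl in place of 4-methoxyphenyl on an aromatic nitrogen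

Going by the values given here, two measured steps bear on this change, since both also replace the 4-methoxyphenyl on the same aromatic nitrogen. The step of a 1.4-fold lower number from compound 1 to compound 2 (0.16 log units; within the scatter) stayed within the scatter, while the step of a 2.2-fold lower number from compound 1 to compound 3 (0.34 log units; beyond the scatter) went modestly beyond it, and both point toward a lower number. For compound 4 a similar modest lowering is expected, though with the small sample it may also fall within the scatter, giving an expected step of a 1.8-fold lower number from compound 1 to compound 4 (0.26 log units; within the scatter). The estimate for compound 4 in this assay is therefore 2600 nM, expected to lie between 1200 nM and 5800 nM.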

Compound 4, half-maximal inhibitory concentration: 2320 nM
For compound 4 the middle estimate is 1.1-fold (0.05 log units) above the measured one; the range from low to high includes it.
By their numbers in this assay, from the lowest: compounds 3, 4, 2 and 1 (each within the scatter of the next, the first and the last beyond it).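

In this assay the change to 2-(trifluoromethyl)phenyl on this aromatic nitrogen gives a 2.0-fold lower number from compound 1 to compound 4 (0.30 log units; within the scatter), so on its own this swap cannot be called a real gain over 4-methoxyphenyl. Compound 4 also cannot be told apart from the two earlier replacements, with a 1.1-fold higher number from compound 3 to compound 4 (0.04 log units; within the scatter) and a 1.4-fold lower number from compound 2 to compound 4 (0.15 log units; within the scatter), which means three quite differently substituted phenyl groups here give numbers that this read-out does not separate. No evidence is available on what lies behind these close numbers.

All the compounds shown keep a substituted phenyl ring on this nitrogen, so it remains open how a plain unsubstituted phenyl would compare. From the compounds shown here alone, it is also open what a phenyl ring bearing an amine or a carboxylic acid, or a longer alkyl chain in place of the ring, would do to the number.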